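Trading Ethyl for Fluoro at the Edge of Detection

The compounds below may be only part of what the source reports. "The series", "measured", "known", "first", "only" and "open" are said of these compounds alone.

Of the compounds shown here, three have so far been measured in an assay on cells for inhibition of HSP60/HSP10 (Homo sapiens), with a stated time of 60 min; on this read-out higher numbers stand for weaker inhibition and lower numbers for stronger inhibition. Compound 1 `CS(=O)(=O)Nc1ccc(-c2nc3cc(NS(=O)(=O)c4ccc(Cl)s4)ccc3o2)cc1` gives 43000 nM in this assay. Compound 2 `CCc1ccc(S(=O)(=O)Nc2ccc(-c3nc4ccccc4o3)cc2)cc1` does not give a number in this assay but only the limit of the measurement, > 100000 nM. Compound 3 `C=Cc1ccc(S(=O)(=O)Nc2ccc3oc(-c4ccccc4)nc3c2)cc1` likewise returns only a limit in this assay, > 100000 nM. Compound 2 therefore stands at the weak end of what has been seen: two of the three values shown sit at the limit of > 100000 nM in this assay, at which 2 of the 3 values shown sit, and only compound 1 gives a number. Within the data shown here, no two measured compounds differ in a single place, so no measured step is available to read from.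

Compound 4 `O=S(=O)(Nc1ccc(-c2nc3ccccc3o2)cc1)c1ccc(F)cc1` has not yet been measured. It differs from compound 2 by fluoro in place of ethyl on an aromatic carbon. Among the measured compounds shown here, with no measured step to lean on, and with compound 2 itself giving only a limit, the expected step in this assay is a number no higher from compound 2 to compound 4 (the limit leaves the size open), that is, no movement beyond the scatter in either direction. Compound 4 is expected to give about 100000 nM in this assay, with a range from 40000 nM to 300000 nM, and the most likely outcome is estimated to be once more a limit rather than a number.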

Compound 4, half-maximal inhibitory concentration: 73000 nM
Compound 4: the middle estimate sits 1.4-fold (0.14 log units) above what was measured; low and high end bracket the measured number.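

In this assay, among these compounds, the exchange of 4-ethylphenyl for 4-fluorophenyl provides the first step in this set that can be read across a single place, an at least 1.3-fold lower number from compound 2 to compound 4 (0.13 log units; that floor lies within the scatter), and it shows that a change on this aromatic carbon can bring a compound from a limit to a number. Compound 4 gives 73000 nM, so fluoro at this place keeps the compound within the range the assay can report, although the step as read does not by itself establish a gain beyond the scatter. The true size of the step stays unknown because compound 2 gives only a limit and not a number: the limit of > 100000 nM in this assay, at which 2 of the 4 values shown sit.

The compounds shown leave open whether an amine, a carboxylic acid, a methoxy group or a longer chain on this same aromatic carbon would move the value further in either direction, and so whether fluoro is a special case at this place. They also leave open whether the same exchange would act alike on the core of compound 3, where the sulfonamide is attached elsewhere.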